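This account rests on a few compounds, and the source may have more. Where it says the series, first, only, none or still open, it means among the compounds named here.

In a functional assay on A549 cells (Homo sapiens) for antiproliferative activity, read by MTT assay, with a stated time of 72 h (on this read-out lower numbers stand for stronger inhibition and higher numbers for weaker inhibition), two compounds on the same core have been read so far. Compound 1 `Cc1ccc(N2C(=O)COc3ccc(-c4cnc5ccccc5c4)cc32)cc1` gives > 40000 nM, which is a limit of the assay and not a number. Compound 2 `O=C1COc2ccc(-c3cnc4ccccc4c3)cc2N1c1ccc(Cl)cc1` gives > 40000 nM, and this too is a limit. Compound 2 therefore stands together with compound 1 at the limit of > 40000 nM in this assay, at which 2 of the 2 values shown sit, with no number to place it more exactly. Compound 3 `O=C1COc2ccc(-c3cnc4ccccc4c3)cc2N1c1ccccc1` differs from compound 2 by one change, (hydrogen in place of chloro on an aromatic carbon), which turns 4-chlorophenyl to phenyl. Among the compounds with values here, the only measured step at this place, the exchange of methyl for chloro, is a step that the two limits leave unreadable from compound 1 to compound 2, so it offers no size to carry over. Neither compound at this place gives a number in this assay, so the data support no direction for the new step, and no real gain is expected from removing the chloro group. The estimated change is a number no higher from compound 2 to compound 3 (the limit leaves the size open), and no step beyond the scatter is expected. Compound 3 is expected to give about 40000 nM, with an estimated range of 15000 nM to 100000 nM, and the read-out will most likely again be only a limit.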

Compound 3, half-maximal inhibitory concentration: > 40000 nM
Compound 3: no number, only a limit; the forecaster's own chance of this, stated with the estimate: 80%; the middle value lies on the limit itself.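

In this assay compound 3 gives > 40000 nM, which is again a limit of the assay and not a number. The steps among compound 1, compound 2 and compound 3 cannot be read, and all three stand together: the limit of > 40000 nM in this assay, at which 3 of the 3 values shown sit.

The compounds shown leave open whether methyl, chloro and hydrogen at this place differ at all in antiproliferative activity.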